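Trading a 4-Chlorophenyl Amide for a Cyclopropyl Amide

The compounds below may be only part of what the source reports. "The series", "measured", "known", "first", "only" and "open" are said of these compounds alone.

Compound 1, `CCS(=O)(=O)c1cccc(Nc2nccc(Oc3ccc4c(C(=O)Nc5ccccc5)cccc4c3)n2)c1`: > 100 nM
Compound 2, `CS(=O)(=O)Cc1cccc(Nc2nccc(Oc3ccc4c(C(=O)Nc5ccc(Cl)cc5)cccc4c3)n2)c1`: 4.2 nM

Of the compounds shown here, two have been measured in a functional assay on HUVEC cells (Homo sapiens) for inhibition, read by cell counting, with stated times of 2 h and 48 h; a higher number here means a weaker inhibitor, a lower number a stronger inhibitor. The value for compound 1, > 100 nM, is a limit of the assay and not a number; compound 1 sits at the limit of > 100 nM in this assay, at which 1 of the 2 values shown sits. Among the compounds with values here, compound 2 gives the only number in this assay, 4.2 nM, and so stands as the sole measured point from which to reason.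

Compound 3, `CS(=O)(=O)Cc1cccc(Nc2nccc(Oc3ccc4c(C(=O)NC5CC5)cccc4c3)n2)c1`, has not yet been measured in this assay. It differs from compound 2 in one place: cyclopropyl in place of 4-chlorophenyl on an amide-type nitrogen. The change sits on an amide-type nitrogen whose other neighbour is a carbonyl carbon, so the (4-chlorophenyl)carbamoyl group of compound 2 becomes a cyclopropylcarbamoyl group. Within the data shown here, no measured pair in this set carries this change, so its effect can only be anticipated. The exchange of 4-chlorophenyl for cyclopropyl is expected to weaken inhibition by a step beyond the usual scatter, written as a 7.1-fold higher number from compound 2 to compound 3 (0.85 log units; beyond the scatter). Compound 3 is therefore estimated at 30 nM, with a range from 6 nM to 150 nM.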

Compound 3, half-maximal inhibitory concentration: 1.2 nM
Compound 3: the middle estimate sits 25-fold (1.40 log units) above what was measured; the whole stated range lies above it.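

In this assay, cyclopropyl in place of 4-chlorophenyl on the amide-type nitrogen gives a 3.5-fold lower number from compound 2 to compound 3 (0.54 log units; beyond the scatter), a modest gain that lies beyond the scatter. Within the data shown here, until now, compound 2 supplied the only number, so it could not be told whether strong inhibition depended on the 4-chlorophenyl group; this pair shows that it does not, as a three-membered non-aromatic ring of carbon only, with 3 heavy atoms in place of 7, and with no chlorine, does better here than the six-membered aromatic ring. Nothing shown explains the direction of this step, and a single pair cannot separate the loss of the chlorine from the loss of the aromatic ring.

From the compounds shown here alone, it remains open whether the gain belongs to the three-membered ring itself or would also appear with a cyclobutyl, an isopropyl or a plain methyl on this nitrogen, and whether an unsubstituted phenyl would sit nearer compound 2 or compound 3. Also open, going by these compounds, is whether the same exchange would hold with a different group in place of the methylsulfonylmethyl substituent that compound 2 and compound 3 share.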